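Swapping fluoro for hydrogen on compound 1

The compounds below may be only part of what the source reports. "The series", "measured", "known", "first", "only" and "open" are said of these compounds alone.

In an ADME assay on MDCK cells (Canis lupus familiaris) for cytotoxicity, read by MTT assay, with a stated time of 72 h (a higher number here means that more compound is tolerated, a lower number that less compound is tolerated), compound 1 (`Cc1nc([N+](=O)[O-])cn1CC(=O)Nc1ccc(F)cc1`) gives 828000 nM. Compound 2 (`Cc1nc([N+](=O)[O-])cn1S(=O)(=O)c1ccc(Cl)cc1`) gives 578000 nM, and these two numbers lie within the usual scatter of each other. Compound 3 (`Cc1nc([N+](=O)[O-])cn1CC(=O)Nc1ccccc1`) differs from compound 1 by one small change: hydrogen in place of fluoro on an aromatic carbon. Within the data shown here, no measured pair of compounds shows the effect of this swap, so no shift beyond the scatter is expected in this assay. The expected change is a 1.0-fold lower number from compound 1 to compound 3 (0.01 log units; within the scatter). Compound 3 is estimated at 800000 nM, with an expected range of 400000 nM to 1600000 nM.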

Compound 3, half-maximal cytotoxic concentration: 1140000 nM
Compound 3: the middle estimate sits 1.4-fold (0.15 log units) below what was measured; low and high end bracket the measured number.
By their numbers in this assay, from the lowest: compounds 2, 1 and 3 (each within the scatter of the next).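

In this assay, placing hydrogen instead of fluoro on the aromatic carbon para to a large group gives a 1.4-fold higher number from compound 1 to compound 3 (0.14 log units; within the scatter) and so stays within the usual scatter. Among these compounds, this is the first direct look at this position, and in this pair of compounds fluoro and hydrogen cannot be told apart. Nothing measured here offers an explanation for this result.

Still open, on these data alone, is whether a methoxy group or an amine at this place would move the number beyond the scatter. Also open, as far as these compounds go, is whether the same swap would behave alike on a different core.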